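The source may report more compounds than this note shows. Statements on the series, on what has been measured and on what is new or still open speak of the compounds shown alone.

Compound 1 `CN(C(=O)c1ccc(F)cc1)c1ccc2[nH]c(-c3n[nH]c4ccccc34)cc2n1` has the lower of the two numbers recorded in a functional assay on KB cells (Homo sapiens) for antiproliferative activity, read by MTT assay, with a stated time of 72 h (on this read-out higher numbers stand for weaker inhibition and lower numbers for stronger inhibition), where compound 1 gives 7220 nM. Compound 2 `CN(C(=O)c1ccc([N+](=O)[O-])cc1)c1ccc2[nH]c(-c3n[nH]c4ccccc34)cc2n1` gives 20200 nM; putting nitro in place of fluoro on an aromatic carbon brought a 2.8-fold higher number from compound 1 to compound 2 (0.45 log units; beyond the scatter). Compound 3 `CN(c1ccc2[nH]c(-c3n[nH]c4ccccc34)cc2n1)S(=O)(=O)c1ccc(Cl)cc1` differs from compound 1 at one place: (4-chlorophenyl)sulfonyl in place of (4-fluorophenyl)carbonyl on a nitrogen on an aromatic ring. Among the measured compounds shown here, no measured step exchanges a carbonyl for a sulfonyl, so the only guide is that the single recorded step was modest. The expected step is a 1.4-fold higher number from compound 1 to compound 3 (0.14 log units; within the scatter). The estimate for compound 3 is 10000 nM, with a range from 3000 nM to 35000 nM.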

Compound 3, half-maximal inhibitory concentration: 8350 nM
The estimate for compound 3 lay 1.2-fold (0.08 log units) above the measured number, and the stated range covers the measured number.
By their numbers in this assay, from the lowest: compounds 1 and 3 (each within the scatter of the next); then compound 2.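

In this assay, replacing (4-fluorophenyl)carbonyl with (4-chlorophenyl)sulfonyl on this nitrogen gave a 1.2-fold higher number from compound 1 to compound 3 (0.06 log units; within the scatter), so a sulfonyl can stand at this position with no change beyond the scatter. The link and the halogen changed together, so the separate contribution of each cannot be read, and the two could be offsetting each other. Nothing available explains this result.

Still open, from the compounds shown here alone, is how an amine or a carboxylic acid on the phenyl ring would read, and whether a sulfonyl carrying a longer chain instead of that ring would read alike.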